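Cytotoxicity limits in the shared-core series and one estimate

The source may report more compounds than this note shows. Statements on the series, on what has been measured and on what is new or still open speak of the compounds shown alone.

Measured so far:
compound 1 `CCCCCCCCOc1nc(N)nc2c1ncn2/C=C1/CC1(CO)CO` in an ADME assay on HFF cells (Homo sapiens) for cytotoxicity, with a stated time of 8 days (a higher number here means that more compound is tolerated, a lower number that less compound is tolerated), gives > 300000 nM, a limit of this assay.
compound 2 `CC(C)CSc1nc(N)nc2c1ncn2/C=C1/CC1(CO)CO` in this assay gives > 300000 nM, a limit.
compound 3 `Nc1nc(N2CCCC2)c2ncn(/C=C3/CC3(CO)CO)c2n1` in this assay gives > 300000 nM, a limit.

Compound 3 stands at the limit of this assay, and the two other values shown sit at the same limit (the limit of > 300000 nM in this assay, at which 3 of the 3 values shown sit). Nothing in the numbers separates compound 3 from compound 1 or compound 2.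

The unmeasured compound 4 `CCCCCCCCSc1nc(N)nc2c1ncn2/C=C1/CC1(CO)CO` differs from compound 3 in one place: octylsulfanyl in place of pyrrolidin-1-yl on an aromatic carbon.

The measured steps that bear on this change are a step that the two limits leave unreadable from compound 1 to compound 3 and a step that the two limits leave unreadable from compound 2 to compound 3, and between the two open-chain groups a step that the two limits leave unreadable from compound 1 to compound 2; none is readable in size, since every value is a limit. With three different groups on this carbon all tolerated to the limit, no step beyond the scatter is expected in this assay.

Compound 4 is therefore expected at 400000 nM, with a range from 150000 nM to 1500000 nM, most likely reported again only as a limit. The step this estimate means, a step that the limit leaves unreadable from compound 3 to compound 4, is expected to stay within the scatter.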

Compound 4, half-maximal cytotoxic concentration: > 300000 nM
Compound 4: a limit, no number (the forecaster's own chance of this, stated with the estimate: 80%); the middle value is on the limit's open side.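

No step can be read between compound 4 and compound 1, compound 2 or compound 3, since all four values are limits: the limit of > 300000 nM in this assay, at which 4 of the 4 values shown sit.

The compounds shown leave open at what concentration cytotoxicity would appear in this assay, and whether the octylsulfanyl, octyloxy, isobutylsulfanyl and pyrrolidin-1-yl groups differ there at all.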